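The source may report more compounds than this note shows. Statements on the series, on what has been measured and on what is new or still open speak of the compounds shown alone.

Of the compounds shown here, three have been tested in a functional assay on CHO-K1 cells for antagonist activity at adenosine receptor A1 (Homo sapiens), read by a beta-galactosidase reporter and cAMP accumulation, with stated times of 15 min and 6 h; a higher number here means a weaker inhibitor, a lower number a stronger inhibitor. Compound 1 `Cc1ccc(-c2nc(N)c3cc(Cc4ccccc4Cl)sc3n2)o1` gives 26.1 nM, compound 2 `Nc1nc(-c2ccc(C3CC3)o2)nc2sc(Cc3ccccc3)cc12` gives 861 nM, and compound 3 `COc1ccccc1Cc1cc2c(N)nc(-c3ccc(C(F)F)o3)nc2s1` gives 516 nM. Compound 2 thus carries the highest of the three numbers; its gap to compound 3 lies within the usual scatter of this assay, whereas its gap to compound 1 lies well beyond it. Compound 4 `Nc1nc(-c2ncco2)nc2sc(Cc3ccccc3)cc12` differs from compound 2 in a single place: 1,3-oxazol-2-yl in place of 5-cyclopropylfuran-2-yl on an aromatic carbon. Among the measured compounds shown here, no pair of measured compounds shows what such a swap does, so the direction of the step is open, and a modest move in either direction seems more likely than a large one. For compound 4 the expected value is 1200 nM, with a likely range from 300 nM to 5000 nM, which corresponds to an expected step of a 1.4-fold higher number from compound 2 to compound 4 (0.14 log units; within the scatter).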

Compound 4, inhibition constant: 310 nM
Compound 4: the middle estimate sits 3.9-fold (0.59 log units) above what was measured, and the stated range covers the measured number.
By their numbers in this assay, from the lowest: compound 1; then compounds 4, 3 and 2 (each within the scatter of the next, the first and the last beyond it).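

In this assay, putting 1,3-oxazol-2-yl in place of 5-cyclopropylfuran-2-yl gives a 2.8-fold lower number from compound 2 to compound 4 (0.44 log units; beyond the scatter), a modest step beyond the scatter. This position, on an aromatic carbon between two ring nitrogen atoms, therefore does not need the larger group with its three-membered ring: the entering ring has fewer heavy atoms and one more hydrogen-bond acceptor, yet the number falls. No measured evidence here explains the step.

From the compounds shown here alone, the ring and the cyclopropyl group change together, so it stays open which of them matters. Also open, going by these compounds, is what a pyridine ring or a plain furan-2-yl would give at this position.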